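This account rests on a few compounds, and the source may have more. Where it says the series, first, only, none or still open, it means among the compounds named here.

Measured so far: compound 1 `Cc1nc(S(C)(=O)=O)ccc1Oc1ncnc(OC2CCN(C(=O)OC(C)C)CC2)c1F` with 142 nM; compound 2 `Cc1nc(S(C)(=O)=O)ccc1Oc1ncnc(OC2CCN(C(=O)C(F)(F)F)CC2)c1F` with 880 nM.

In a functional assay on isolated protein for inhibition of Glucose-dependent insulinotropic receptor (Rattus norvegicus), read by HTRF and cAMP accumulation (a lower number here means that less compound is needed, a higher number that more compound is needed for the effect), compound 2 stands at the higher of the two numbers, the step of a 6.2-fold higher number from compound 1 to compound 2 (0.79 log units; beyond the scatter) lying beyond the scatter. Compound 3 `CCC(F)(F)C(=O)N1CCC(Oc2ncnc(Oc3ccc(S(C)(=O)=O)nc3C)c2F)CC1` is not yet measured; it differs from compound 2 by ethyl in place of fluoro on a saturated chain carbon bound to a carbonyl carbon and two fluorine atoms. Among the measured compounds shown here, only one measured step bears on this position on the carbonyl carbon: isopropoxy to trifluoromethyl gave a 6.2-fold higher number from compound 1 to compound 2 (0.79 log units; beyond the scatter). The change trifluoromethyl to 1,1-difluoropropyl goes in the opposite sense in size, so the expected step is a 2.0-fold lower number from compound 2 to compound 3 (0.29 log units; within the scatter), a modest lowering. Compound 3 is estimated at 450 nM, range 150 nM to 1300 nM.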

Compound 3, half-maximal effective concentration: 69.2 nM
Beside the measured number, compound 3's estimate is 6.5-fold (0.81 log units) above it; measured number outside the range, below it.
By their numbers in this assay, from the lowest: compound 3; then compound 1; then compound 2.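

In this assay, ethyl in place of fluoro on a saturated chain carbon bound to a carbonyl carbon and two fluorine atoms gives a 13-fold lower number from compound 2 to compound 3 (1.10 log units; beyond the scatter), a large step from a small change in one group. The earlier pair showed only a rise at the carbonyl carbon; now 1,1-difluoropropyl in place of isopropoxy gives a 2.1-fold lower number from compound 1 to compound 3 (0.31 log units; beyond the scatter), so a replacement of isopropoxy can also lower the number. Nothing available accounts for either step.

Still open, as far as these compounds go, is whether a longer chain than ethyl lowers the number further. Also open, from the compounds shown here alone, is how an amine in place of ethyl behaves, and whether the two fluorine atoms are needed.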